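Two Bromo Analogues and an Expected Dimethylamino Analogue

A few compounds are considered here, and "the series" means these few. Any claim that something is new, unique, unknown or untested is made for them only; others in the source may bear on it.

Compound 1 `COc1cc(Br)c(C2C(C#N)=C(N)OC(c3c[nH]c4ccccc34)=C2C#N)cc1OC` and compound 2 `N#CC1=C(N)OC(c2c[nH]c3ccccc23)=C(C#N)C1c1ccc(Br)cc1` share one core. In a functional assay, tested at 50 ug/mL (a lower number here means a weaker effect, a higher number a stronger effect of the compound at the concentration tested), compound 1 gives 18.5% and compound 2 gives 14.2%, two readings within the usual scatter of each other, so compound 2 stands as the lower of two numbers that do not separate. Compound 3 `CN(C)c1ccc(C2C(C#N)=C(N)OC(c3c[nH]c4ccccc34)=C2C#N)cc1` is not yet measured and differs from compound 2 in one place: dimethylamino in place of bromo on an aromatic carbon. For the measured compounds named here, no measured pair shows what this change does. The step of a number 1.8 percentage points higher from compound 2 to compound 3 (within the scatter) in this assay is therefore expected to stay within the scatter, in no firm direction. Compound 3 is estimated at 16%, with a range from 4% to 36%.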

Compound 3, a percentage reported as activity, at one concentration (the size of the read-out at that concentration, not a potency): 14.4%
For compound 3 the middle estimate is 1.6 percentage points above the measured one; the measured number falls inside the stated range.
By their numbers in this assay, from the lowest: compounds 2, 3 and 1 (each within the scatter of the next).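

For the compounds shown here, this is the first pair in the set that differs in one place, and in this assay the exchange of bromo for dimethylamino on the aromatic carbon, para to a large group, comes to a number 0.2 percentage points higher from compound 2 to compound 3 (within the scatter). At this position, then, a group of three heavy atoms carrying a hydrogen-bond acceptor reads the same as a single bromine. Nothing measured here accounts for this. Still open, from the compounds shown here alone, is whether a carboxylic acid or a longer chain at this position would give a reading that separates from these.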